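The source may report more compounds than this note shows. Statements on the series, on what has been measured and on what is new or still open speak of the compounds shown alone.

Measured so far in a functional assay on PC-3 cells (Homo sapiens), with a stated time of 24 h; on this read-out higher numbers stand for weaker inhibition and lower numbers for stronger inhibition
- compound 1 `O=C(Nc1ccc(Cl)cc1)C1CCCN(C(=O)c2cccc(-c3cccs3)c2)C1` gives 4500 nM
- compound 2 `O=C(Nc1ccc(Cl)cc1)C1CCCN(C(=O)c2cc(C(F)(F)F)cc(C(F)(F)F)c2)C1` gives 17000 nM

Compound 1 stands lowest of these two numbers, so it is the stronger inhibitor of the pair. Compound 2 lies higher by a gap beyond the usual scatter. Among the compounds with values here, with only two values, and no pair of measured compounds that differs in one place, the series offers no measured step to lean on.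

Compound 3 `O=C(Nc1ccc(Cl)cc1)C1CCCN(C(=O)c2cccc(-c3ccco3)c2)C1` has yet to be tested. It departs from compound 1 in one place: furan-2-yl in place of thiophen-2-yl on an aromatic carbon, meta to a large group. The counted difference is furan-2-yl in place of thiophen-2-yl on an aromatic carbon and shows the same ring size and the same number of heavy atoms on both sides.

With so little changing, no step beyond the scatter is expected in this assay, with at most a slight drift towards a higher number. The expected move is a 1.2-fold higher number from compound 1 to compound 3 (0.09 log units; within the scatter) and stays small. For compound 3 the estimated value is 5500 nM within an expected range from 2200 nM to 14000 nM in this read-out.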

Compound 3, half-maximal inhibitory concentration in the PC-3 assay: 4200 nM
Compound 3: the middle estimate sits 1.3-fold (0.12 log units) above what was measured; the measured number falls inside the stated range.
By their numbers in the PC-3 assay, from the lowest: compounds 3 and 1 (each within the scatter of the next); then compound 2.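

At this position, on an aromatic carbon meta to a large group, furan-2-yl in place of thiophen-2-yl gives a 1.1-fold lower number from compound 1 to compound 3 (0.03 log units; within the scatter) in the PC-3 assay, so this exchange of one five-membered aromatic ring for another leaves the inhibition numbers within the scatter of each other. Unlike the earlier pair, this pair differs in one place only, so the series now has a step that can be read directly. The same exchange does separate the pair in a physicochemical assay for solubility, measured as kinetic solubility (on this read-out lower numbers stand for lower solubility and higher numbers for higher solubility), where furan-2-yl goes with the higher solubility while the inhibition numbers stay within the scatter: the measured solubility of compound 1, 1.36 ug/mL, and of compound 3, 3.09 ug/mL, a 2.3-fold higher number (0.36 log units; beyond the scatter) In the physicochemical assay compound 1 gives 1.36 ug/mL and compound 3 gives 3.09 ug/mL.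

Both groups compared here are five-membered aromatic rings with one hetero atom, so the compounds shown leave open how far this position accepts anything of a different kind. A pyridin-3-yl ring, a morpholine or a carboxylic acid on the same aromatic carbon would show whether solubility and inhibition can be moved apart further, or whether the two read-outs begin to shift together once the group departs from this ring type.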